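Ring Contraction at the Amine Side of Compound 1

The compounds below may be only part of what the source reports. "The series", "measured", "known", "first", "only" and "open" are said of these compounds alone.

Compound 1 `CCC(C(=O)N[C@@H](CC(=O)O)C(=O)CNCN1CCc2ccccc2C1)n1ccnc(NCc2nonc2C)c1=O` is one of two measured members of this series. In an assay for inhibition of Caspase-8 (Homo sapiens) (on this read-out lower numbers stand for stronger inhibition and higher numbers for weaker inhibition), compound 1 gives 7380 nM, the highest of the two numbers recorded so far. Within the data shown here, its only neighbour, compound 2 `CCC(C(=O)N[C@@H](CC(=O)O)C(=O)CSCc1ccccc1)n1ccnc(NCc2nc(C)no2)c1=O`, gives 6420 nM in this assay, and the two values lie within the usual scatter of each other, so neither can be called weaker or stronger than the other. Among the measured compounds shown here, the two differ in more than one place, so no single step between them is counted.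

Compound 3 `CCC(C(=O)N[C@@H](CC(=O)O)C(=O)CNCN1Cc2ccccc2C1)n1ccnc(NCc2nonc2C)c1=O` has not yet been measured. It differs from compound 1 in one place: a group of 9 heavy atoms (8 carbon, 1 nitrogen; one five-membered non-aromatic ring with 1 hetero atom, one six-membered aromatic ring of carbon only) in place of a group of 10 heavy atoms (9 carbon, 1 nitrogen; one six-membered non-aromatic ring with 1 hetero atom, one six-membered aromatic ring of carbon only), on a saturated chain carbon bound to an amine nitrogen. A six-membered non-aromatic ring is thus replaced by a five-membered one, while the aromatic ring of carbon only and the single hydrogen-bond acceptor remain.

For the measured compounds named here, no measured pair shows what such a change does here. The expected step is small, most likely within the scatter and with no clear direction, namely a 1.1-fold lower number from compound 1 to compound 3 (0.02 log units; within the scatter). Compound 3 is therefore expected to give about 7000 nM in this assay, with a range from 2500 nM to 20000 nM.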

Compound 3, half-maximal inhibitory concentration: 4290 nM
Compound 3: the middle estimate sits 1.6-fold (0.21 log units) above what was measured; the range from low to high includes it.
By their numbers in this assay, from the lowest: compounds 3, 2 and 1 (each within the scatter of the next).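

Among these compounds, this is the first step that changes one place only, and it gives that place a reading in this assay: replacing 1,2,3,4-tetrahydroisoquinolin-2-yl with the group carrying the five-membered non-aromatic ring gives a 1.7-fold lower number from compound 1 to compound 3 (0.24 log units; within the scatter). On a saturated chain carbon bound to an amine nitrogen, the six-membered non-aromatic ring can therefore give way to a five-membered one, with the aromatic ring of carbon only and the hydrogen-bond acceptor kept, and no change can be told from the scatter. Nothing measured alongside this result bears on what lies behind it.

A single step within the scatter cannot show whether this place is insensitive to its group in general or only tolerates this one small change in ring size. The compounds shown leave open what a group of a different kind would do on the same chain carbon, such as a simple dimethylamine, a carboxylic acid or a longer chain ending in a phenyl ring, and whether any such group would move the number beyond the scatter.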